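A few compounds are considered here, and "the series" means these few. Any claim that something is new, unique, unknown or untested is made for them only; others in the source may bear on it.

Three compounds of this set share one core, and one more has yet to be tested. Compound 1 `COc1ccc(-c2ccccc2)c2cc(C(=O)Nc3ccc(F)cc3)oc12` has no result in a functional assay on the whole organism for inhibition, with Mus musculus as the target, at a dose of 10 mg/kg by the oral route; on this read-out higher numbers stand for more inhibition at the one dose given (going by the name of the read-out) and lower numbers for less inhibition: for compound 1 the entry reads "not determined" (no result reported). Compound 2 `CNC(=O)c1cc2c(-c3ccccc3)ccc(OC)c2o1` gives 18%, the lower of the two numbers reported. Within the data shown here, compound 3 `COc1ccc(-c2ccccc2)c2cc(C(=O)Nc3c(Cl)cncc3Cl)oc12` gives 74%, and the step of a number 56 percentage points higher from compound 2 to compound 3 (beyond the scatter) is the only measured step; it puts 3,5-dichloropyridin-4-yl in place of methyl on an amide-type nitrogen.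

Compound 4 `COC(=O)Nc1cc2c(-c3ccccc3)ccc(OC)c2o1` differs from compound 2 by (methoxycarbonyl)amino in place of methylcarbamoyl on an aromatic carbon. Among the measured compounds shown here, no measured step bears on this kind of change: the single known step alters what sits on the amide-type nitrogen and keeps the rest of the methylcarbamoyl group, whereas here the whole methylcarbamoyl group leaves and a (methoxycarbonyl)amino group enters on the aromatic carbon next to the ring oxygen. The data therefore give no ground to expect the large rise seen from compound 2 to compound 3, nor a fall, and the step from compound 2 to compound 4 is expected to stay within the scatter, at a number 4 percentage points higher from compound 2 to compound 4 (within the scatter). Compound 4 is thus estimated at 22%, with a range from 5% to 50%.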

Compound 4, a percentage reported as inhibition, in the whole organism at one dose (the size of the read-out at that dose, not a potency): 86%
Beside the measured number, compound 4's estimate is 64 percentage points below it; the measured number lies above the stated range.
By their numbers in this assay, from the lowest: compound 2; then compound 3; then compound 4.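

In this assay, replacing methylcarbamoyl with (methoxycarbonyl)amino on the aromatic carbon next to the ring oxygen gives a number 68 percentage points higher from compound 2 to compound 4 (beyond the scatter), so the result can change strongly with the group attached at this carbon, and not only with what sits on the amide-type nitrogen. Neither group has a ring or a net charge, so this large step arises without bringing either feature into the group at this place. No measurement shown explains why this change has so large an effect on inhibition in the whole organism.

The compounds shown leave open which part of the (methoxycarbonyl)amino group matters, and a simple amine, an acetylamino group or an ethoxycarbonylamino group on the same carbon would help to separate the contributions of its parts. On these data alone, it also remains open whether a carboxylic acid at this carbon would fit the same trend, and whether 3,5-dichloropyridin-4-yl, which gave a number 56 percentage points higher from compound 2 to compound 3 (beyond the scatter), would have any comparable effect when joined to the nitrogen of the new group.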